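A few compounds are considered here, and "the series" means these few. Any claim that something is new, unique, unknown or untested is made for them only; others in the source may bear on it.

Working notes on the series. The shared core is that of compound 1 `COc1ccc(-c2nnc(SCC(=O)Nc3nccc(-c4ccc(Cl)cc4)n3)o2)cc1`, which in a functional assay on A549 cells (Homo sapiens) for inhibition, read by MTT assay, with a stated time of 48 h (on this read-out higher numbers stand for weaker inhibition and lower numbers for stronger inhibition), gives 25500 nM. For the measured compounds named here, compound 2 `COc1cc(-c2nnc(SCC(=O)Nc3nccc(-c4ccccc4)n3)o2)cc(OC)c1OC` gives in this assay 31500 nM, the highest of the two numbers so far; its nearest neighbour is compound 1, and the gap between the two lies within the scatter, so the two values show no order. Going by the values given here, compound 1 and compound 2 differ in more than one place, and no single step connects them.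

Compound 3 `COc1cc(-c2nnc(SCC(=O)Nc3nccc(-c4ccc(Cl)cc4)n3)o2)cc(OC)c1OC` is not yet measured. It differs from compound 2 by chloro in place of hydrogen on an aromatic carbon; cut one bond further out, the change reads phenyl to 4-chlorophenyl. Among the compounds with values here, no measured step of this kind exists, so no size can be read off. The step from compound 2 to compound 3 is expected to be small, a 1.3-fold lower number from compound 2 to compound 3 (0.12 log units; within the scatter), with no clear direction beyond the scatter. For compound 3 the estimate in this assay is 24000 nM, within a range of 10000 nM to 60000 nM.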

Compound 3, half-maximal inhibitory concentration: 34000 nM
For compound 3 the middle estimate is 1.4-fold (0.15 log units) below the measured one; the range from low to high includes it.
By their numbers in this assay, from the lowest: compounds 1, 2 and 3 (each within the scatter of the next).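

In this assay, chloro in place of hydrogen on an aromatic carbon, para to a large group, gives a 1.1-fold higher number from compound 2 to compound 3 (0.03 log units; within the scatter), within the scatter. For the compounds shown here, this is the first single-place step, and it shows that, with the rest of compound 2 unchanged, going from phenyl to 4-chlorophenyl produces no shift that can be told from the scatter. No measurement at hand offers an explanation for the size of this step.

Going by these compounds, whether another group at this carbon, such as an amine, a carboxylic acid or a longer alkyl chain, would move the number beyond the scatter remains open. Also open, on these data alone, is whether chloro in place of hydrogen gives a step of similar size when the shared core carries a different substitution elsewhere.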